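A few compounds are considered here, and "the series" means these few. Any claim that something is new, unique, unknown or untested is made for them only; others in the source may bear on it.

Compound 1 `Cc1cc(N2CCC(N3CCCC3C)C2)ccc1NC(=O)C1CCCO1` is the starting point here. For the measured compounds named here, in an assay on CHO cells for displacement of a labelled ligand from histamine receptor H3 (Macaca mulatta) (a lower number here means a stronger inhibitor, a higher number a weaker inhibitor), compound 1 gives 7.34 nM, the lowest of the two numbers measured so far. Its nearest neighbour is compound 2 `Cc1cc(N2CCC(N3CCCC3C)C2)ccc1NC(=O)C1CC1`, which in this assay gives 9.6 nM; the step of a 1.3-fold higher number from compound 1 to compound 2 (0.12 log units; within the scatter) is within the scatter, so the two compounds cannot be told apart on potency. Compound 3 `Cc1cc(N2CC[C@H](N3CCC[C@@H]3C)C2)ccc1NC(=O)C1CCCO1` has not yet been measured. It differs from compound 1 as follows: the two compounds have the same atoms and bonds; at least one stereo element is drawn with a configuration in one of them and without one in the other: 2 of 3 stereo elements differ; a stereocentre at a saturated ring carbon is drawn without a configuration in compound 1 and S in compound 3; a stereocentre at a saturated ring carbon is drawn without a configuration in compound 1 and S in compound 3. Going by the values given here, the only measured step, the exchange of the group on the carbonyl carbon from compound 1 to compound 2, changes atoms rather than drawn configurations, so no measured step bears directly on this change. Picking out one drawn configuration of a compound whose configurations are unspecified often lowers the number somewhat, since the mixture can contain a weaker partner. For compound 3 the expected step is therefore a 1.5-fold lower number from compound 1 to compound 3 (0.17 log units; within the scatter), and the estimate is 5 nM, within a range of 2 nM to 14 nM.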

Compound 3, inhibition constant: 7.33 nM
Compound 3: the middle estimate sits 1.5-fold (0.17 log units) below what was measured; the measured number falls inside the stated range.
By their numbers in this assay, from the lowest: compounds 3, 1 and 2 (each within the scatter of the next).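

Drawing the two saturated ring carbons as S gives a 1.0-fold lower number from compound 1 to compound 3 (0.00 log units; within the scatter) in this assay, so compound 1 and compound 3 cannot be told apart on potency. For the compounds shown here, the earlier compounds spoke only to the group on the carbonyl carbon, whereas this pair is the first to speak to the drawn configuration, and this S,S form binds in the same range as the compound drawn without one. The whole comparison rests on a single point: the fact that one of compounds 1 and 3 is drawn with a defined configuration and the other without, at the place where they differ.

The compounds shown leave open how a form with R at either of these ring carbons would read, and what the third stereo element, undrawn in both compounds, contributes. They also leave open whether an amine or a longer chain in place of oxolan-2-yl on the carbonyl carbon would keep this potency.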